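A few compounds are considered here, and "the series" means these few. Any claim that something is new, unique, unknown or untested is made for them only; others in the source may bear on it.

Measured in a physicochemical assay for solubility, in phosphate buffer, at pH 7.4; on this read-out lower numbers stand for lower solubility and higher numbers for higher solubility:
- compound 1 `CCOC(=O)c1c(-c2ccc(OC)cc2)[nH]c2cccc(OC)c2c1=O`: > 100000 nM (a limit)
- compound 2 `CCOC(=O)c1c(-c2cccc(C)c2)[nH]c2cc(OC)ccc2c1=O`: 48000 nM
- compound 3 `CCOC(=O)c1c(-c2ccccc2Cl)[nH]c2cc(OC)ccc2c1=O`: 28000 nM

Compound 1 has no number, only a limit: the limit of > 100000 nM in this assay, at which 1 of the 3 values shown sits.

Compound 4 `CCOC(=O)c1c(-c2ccccc2)[nH]c2cccc(OC)c2c1=O` is still unmeasured. The change is hydrogen in place of methoxy on an aromatic carbon, or 4-methoxyphenyl to phenyl. Among the measured compounds shown here, no measured step removes that methoxy. The nearest evidence is a different aryl swap, 2-chlorophenyl in place of 3-methylphenyl, which gives a 1.7-fold lower number from compound 2 to compound 3 (0.23 log units; within the scatter). On that basis, no step beyond the scatter is expected in this assay, in either direction.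

The expected step is an at least 1.1-fold lower number from compound 1 to compound 4 (0.04 log units; that floor lies within the scatter), a rough figure since it starts from a limit.

Compound 4 is estimated at 90000 nM, with an expected range of 40000 nM to 200000 nM.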

Compound 4, solubility: > 100000 nM
Compound 4 gave a limit, no number (the forecaster's own chance of this, stated with the estimate: 45%); middle value at least 1.1-fold (0.04 log units) from the limit.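

No step can be read from compound 1 to compound 4 in this assay, because each of the two gives only a limit: the limit of > 100000 nM in this assay, at which 2 of the 4 values shown sit.

The compounds shown leave open whether hydrogen in place of methoxy shifts the read-out in this assay at all.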